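The source may report more compounds than this note shows. Statements on the series, on what has been measured and on what is new or still open speak of the compounds shown alone.

Measured compounds in a functional assay on FM3A cells (Mus musculus) for antiproliferative activity, with a stated time of 48 h; on this read-out lower numbers stand for stronger inhibition and higher numbers for weaker inhibition:

compound 1, `C=C(Br)C(=O)Nc1ccc(/C=C/C(=O)c2ccc(I)cc2)cc1`, compound 1 gives 8300 nM
compound 2, `C=C(Br)C(=O)Nc1ccc(/C=C/C(=O)c2cc(OC)c(OC)c(OC)c2)cc1`, compound 2 gives 950 nM
compound 3, `Nc1ccc(/C=C/C(=O)c2ccc(I)cc2)cc1`, compound 3 gives 110000 nM

Compound 2 stands lowest of the three in this assay; its steps to compound 1 and to compound 3 both lie beyond the scatter, so it is the most potent of the measured set. How the core of compound 1 and the core of compound 2 differ is not broken down here.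

Compound 1 and compound 3 share one core and differ in one place: hydrogen in place of (1-bromoethenyl)carbonyl on a nitrogen on an aromatic ring. In this assay the step was a 13-fold higher number from compound 1 to compound 3 (1.12 log units; beyond the scatter), a large loss of potency.

Compound 4, `COc1cc(C(=O)/C=C/c2ccc(N)cc2)cc(OC)c1OC`, is not yet measured. It stands to compound 2 as compound 3 stands to compound 1: hydrogen in place of (1-bromoethenyl)carbonyl on a nitrogen on an aromatic ring. The place lines of the two changes agree word for word, so this is the same change made on a second core. Only this one earlier example of the change exists among the compounds shown, and the two cores themselves differ in a way that is not broken down, so the carry-over is uncertain.

Resting on compound 1 and compound 3, where the step was a 13-fold higher number from compound 1 to compound 3 (1.12 log units; beyond the scatter), compound 4 is expected to lose potency against compound 2 by a step of about a 13-fold higher number from compound 2 to compound 4 (1.10 log units; beyond the scatter). Compound 4 is accordingly estimated at 12000 nM, with a range from 4000 nM to 40000 nM.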

Compound 4, half-maximal inhibitory concentration: 36000 nM
Estimate against measurement, compound 4: 3.0-fold (0.48 log units) below; the range from low to high includes it.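

Replacing the (1-bromoethenyl)carbonyl on the nitrogen with hydrogen cost potency on the second core as well: in this assay the step was a 38-fold higher number from compound 2 to compound 4 (1.58 log units; beyond the scatter), again a large one. Set beside the earlier case, the change points the same way on both cores, but its size does not carry over unchanged: the same change on two cores in this assay, a 13-fold higher number (1.12 log units; beyond the scatter) from compound 1 to compound 3 and a 38-fold higher number (1.58 log units; beyond the scatter) from compound 2 to compound 4, 2.9-fold (0.46 log units) apart, beyond the scatter of two such steps. In this series, then, the direction of the change carried from the core of compound 1 to the core of compound 2 while its size did not, yet two cores establish no general rule, and these data do not show which difference between the cores goes with the larger step.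

The compounds shown leave open which part of the (1-bromoethenyl)carbonyl matters, as the nitrogen carries only that group or hydrogen among them; an acetyl group, or a propenoyl group without the bromine, on the same nitrogen would separate those parts. Also open, going by these compounds, is how large the step would be on a third core, for instance one carrying a chlorine in place of the iodine.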